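Chain length and hexokinase-2 inhibition: a single step

The compounds below may be only part of what the source reports. "The series", "measured", "known", "first", "only" and "open" are said of these compounds alone.

Measured so far:
compound 1 `Nc1ncnc2c1nc(NCCCCCCCCNC(=O)CI)n2[C@@H]1O[C@H](COP(=O)(O)OP(=O)(O)OP(=O)(O)O)[C@@H](O)[C@H]1O` gives 0% in an assay on isolated protein for inhibition of hexokinase-2 (Rattus norvegicus), with a stated time of 6 h, tested at 10 mM; on this read-out lower numbers stand for less inhibition and higher numbers for more inhibition at the one concentration tested (going by the name of the read-out)
compound 2 `Nc1ncnc2c1nc(NCCCCNC(=O)CI)n2[C@@H]1O[C@H](COP(=O)(O)OP(=O)(O)OP(=O)(O)O)[C@@H](O)[C@H]1O` gives 0% in this assay

Going by the values given here, compound 2 stands level with compound 1 at the digits reported; the only measured step, no change at the digits printed from compound 1 to compound 2 (within the scatter), shows that shortening the chain between the ring nitrogen and the iodoacetamide produced nothing beyond the scatter. Both compounds sit at the floor of the read-out, so there is no measured movement anywhere in this small set.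

Compound 3 `Nc1ncnc2c1nc(NCCCCCCNC(=O)CI)n2[C@@H]1O[C@H](COP(=O)(O)OP(=O)(O)OP(=O)(O)O)[C@@H](O)[C@H]1O` has not yet been tested. Its difference from compound 2 is 2-(((iodomethyl)carbonyl)amino)ethyl in place of ((iodomethyl)carbonyl)amino on a saturated chain carbon, four bonds along the chain from a nitrogen on an aromatic ring, that is, a chain two carbons longer than in compound 2 and two carbons shorter than in compound 1. Among the compounds with values here, the one step that bears on this change is no change at the digits printed from compound 1 to compound 2 (within the scatter), and it was flat. Compound 3 therefore lies between two compounds that share the same reading, and the expected step of no change at the digits printed from compound 2 to compound 3 (within the scatter) is none beyond the scatter. Compound 3 is estimated to give 0% in this assay, with a range from -5% to 10%.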

Compound 3, a percentage reported as inhibition, at one concentration (the size of the read-out at that concentration, not a potency): 0%
Compound 3: the middle estimate sits on the measured number at the digits printed; the measured number falls inside the stated range.
By their numbers in this assay, from the lowest: compounds 1, 2 and 3 (each within the scatter of the next).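

With compound 3 added, three chain lengths are on record in this assay, and the new steps read no change at the digits printed from compound 2 to compound 3 (within the scatter) and no change at the digits printed from compound 1 to compound 3 (within the scatter). Going by these compounds alone, the earlier pair covered only the two outer lengths, whereas the intermediate 2-(((iodomethyl)carbonyl)amino)ethyl chain now shows that compound 1, compound 2 and compound 3 all give the same reading, with no compound among them going against that flat pattern. All three sit at the floor of the read-out, so chain length within this set produces no measurable difference, and no supporting data are available to explain this reading.

What the compounds shown leave open is whether any chain on this core can register inhibition at all, since a floor reading gives no direction in which to extend the series. Going by these compounds, it also remains open whether a chain shorter than that of compound 2, a chain longer than that of compound 1, or a chloroacetamide, an acrylamide or a free amine at the chain end in place of the ((iodomethyl)carbonyl)amino group would read any differently.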